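The source may report more compounds than this note shows. Statements on the series, on what has been measured and on what is new or still open speak of the compounds shown alone.

Three compounds, all built on one shared core, have been measured in an ADME assay, in phosphate buffer, with a stated time of 30 min, tested at 1 mM, at a dose of 1 mM; on this read-out lower numbers stand for lower exposure and higher numbers for higher exposure at the dose given:

Compound 1 `O=c1sn(-c2ccc(F)cc2)c(=O)n1-c1ccccc1` gives < 2000 nM, which is a limit of the assay rather than a number.
Compound 2 `COc1ccc(-n2sc(=O)n(-c3ccc(C)cc3)c2=O)cc1` gives < 2000 nM, again a limit.
Compound 3 `COc1ccc(-n2sc(=O)n(-c3ccccc3)c2=O)cc1` gives < 2000 nM, also a limit.

Compound 3 therefore stands at the same limit as the other two, and this is the whole of what the numbers show: the limit of < 2000 nM in this assay, at which 3 of the 3 values shown sit. Two single changes lead to compound 3. The step that the two limits leave unreadable from compound 1 to compound 3 and the step that the two limits leave unreadable from compound 2 to compound 3 both have no readable size, since limits sit at both ends.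

Compound 4 `O=c1sn(-c2ccccc2)c(=O)n1-c1ccccc1` has not yet been measured. It differs from compound 3 by hydrogen in place of methoxy on an aromatic carbon. The two measured steps offer no readable size and no direction, so they give no ground to expect a step beyond the scatter. The step that the limit leaves unreadable from compound 3 to compound 4 is estimated to stay within the scatter. Compound 4 is expected to give 1000 nM, with a range from 250 nM to 2500 nM, most likely again reported as a limit.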

Compound 4, maximal plasma concentration: < 2000 nM
Compound 4: no number, only a limit; the forecaster's own chance of this, stated with the estimate: 70%; the middle value does not contradict the limit.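

Among these compounds, compound 4 also gives only a limit, so no step to it from compound 1 or compound 3 can be read, and the series stays at one shared limit: the limit of < 2000 nM in this assay, at which 4 of the 4 values shown sit. The compounds shown leave open whether any of these changes alters the result in this assay, and what actual number lies behind each limit.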